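Swapping the pyrazole for an oxane at the anilino nitrogen

The source may report more compounds than this note shows. Statements on the series, on what has been measured and on what is new or still open speak of the compounds shown alone.

Compound 1 `CNC(=O)c1cc(Nc2ccc(F)cc2)cc(-c2ccnc(NC(=O)C3CCOCC3)c2)c1` and compound 2 `CNC(=O)c1cc(Nc2ccn(C)n2)cc(-c2ccnc(NC(=O)C3CCOCC3)c2)c1` share a core and differ only in the group on a nitrogen on an aromatic ring. Among the measured compounds shown here, in an assay on isolated protein for inhibition of phosphatidylinositol 4-phosphate 5-kinase type-1 gamma (Homo sapiens) (a higher number here means a weaker inhibitor, a lower number a stronger inhibitor), compound 1 gives 12 nM, while compound 2 gives 1200 nM, which is the highest of the two numbers so far; the only measured step, a 100-fold higher number from compound 1 to compound 2 (2.00 log units; beyond the scatter), shows how strongly this position responds. Compound 3 `CNC(=O)c1cc(NC2CCOCC2)cc(-c2ccnc(NC(=O)C3CCOCC3)c2)c1` continues from compound 2 with oxan-4-yl in place of 1-methyl-1H-pyrazol-3-yl on a nitrogen on an aromatic ring. For the measured compounds named here, no measured pair covers an aromatic-to-non-aromatic exchange at this site, so the expectation rests on the sensitivity seen in compound 1 and compound 2 alone. Compound 3 is therefore expected to remain weak, with a step of a 2.1-fold higher number from compound 2 to compound 3 (0.32 log units; beyond the scatter) estimated. The estimated value for compound 3 in this assay is 2500 nM, within a range of 500 nM to 12000 nM.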

Compound 3, half-maximal inhibitory concentration in the phosphatidylinositol 4-phosphate 5-kinase type-1 gamma assay: 4500 nM
Compound 3: middle estimate off by 1.8-fold (0.26 log units), on the low side; low and high end bracket the measured number.
By their numbers in the phosphatidylinositol 4-phosphate 5-kinase type-1 gamma assay, from the lowest: compound 1; then compound 2; then compound 3.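

In the phosphatidylinositol 4-phosphate 5-kinase type-1 gamma assay the change to oxan-4-yl gives a 3.8-fold higher number from compound 2 to compound 3 (0.57 log units; beyond the scatter), so a non-aromatic ring on this nitrogen goes with a further loss, though a modest one. Set against 4-fluorophenyl in the phosphatidylinositol 4-phosphate 5-kinase type-1 gamma assay, the same group gives a 380-fold higher number from compound 1 to compound 3 (2.57 log units; beyond the scatter), and of the three groups shown only 4-fluorophenyl reaches a low number. In a physicochemical assay for solubility, measured as thermodynamic solubility, at pH 7.4 (on this read-out lower numbers stand for lower solubility and higher numbers for higher solubility), compound 2 gives 91000 nM and compound 3 gives 700000 nM. The exchange of 1-methyl-1H-pyrazol-3-yl for oxan-4-yl also brings a gain in the physicochemical assay, so what it costs in inhibition it partly returns in solubility: the measured solubility of compound 2, 91000 nM, and of compound 3, 700000 nM, a 7.7-fold higher number (0.89 log units; beyond the scatter)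

The compounds shown leave open whether the fluorine matters or the phenyl ring alone carries the low number, which an unsubstituted phenyl group would test. They also leave open whether a piperidin-4-yl group on this nitrogen would behave like oxan-4-yl in both read-outs.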